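Side-chain swaps on the shared core: outlook for compound 4

A few compounds are considered here, and "the series" means these few. Any claim that something is new, unique, unknown or untested is made for them only; others in the source may bear on it.

Compound 1 `CN1CCN(Cc2nnc(-c3cc(S(N)(=O)=O)c(SCc4ccccc4)cc3Cl)o2)CC1` carries a (4-methylpiperazin-1-yl)methyl group on the shared core. In a functional assay on HCT-116 cells (Homo sapiens) for cytotoxicity, read by MTT assay, with a stated time of 72 h (on this read-out lower numbers stand for stronger inhibition and higher numbers for weaker inhibition), compound 1 gives 75000 nM. Compound 2 `CC(C)(O)c1cn(Cc2nnc(-c3cc(S(N)(=O)=O)c(SCc4ccccc4)cc3Cl)o2)nn1` gives 82000 nM in this assay, and compound 3 `NS(=O)(=O)c1cc(-c2nnc(Cn3cc(-c4ccccc4)nn3)o2)c(Cl)cc1SCc1ccccc1` gives 75000 nM. On these numbers compound 1 stands level with compound 3 at the digits printed, the two together the lowest of the three, with compound 2 its furthest neighbour; all three values sit close together and every gap between them is within the scatter.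

Compound 4 `NS(=O)(=O)c1cc(-c2nnc(/C=C/c3ccccc3)o2)c(Cl)cc1SCc1ccccc1` differs from compound 1 by 2-phenylethenyl in place of (4-methylpiperazin-1-yl)methyl on an aromatic carbon. The measured steps that bear on this are the two earlier replacements of the 4-methylpiperazin-1-yl on the saturated chain carbon: a 1.1-fold higher number from compound 1 to compound 2 (0.04 log units; within the scatter) and no change at the digits printed from compound 1 to compound 3 (within the scatter). Among the compounds with values here, the change to compound 4 goes further, since the saturated chain carbon leaves as well and a double bond outside aromatic rings enters; no measured pair tests that part. Because both known steps, a 1.1-fold higher number from compound 1 to compound 2 (0.04 log units; within the scatter) and no change at the digits printed from compound 1 to compound 3 (within the scatter), were flat, the expectation for compound 4 is no step beyond the scatter, no change at the digits printed from compound 1 to compound 4 (within the scatter). The estimate for compound 4 in this assay is 75000 nM, with a range from 35000 nM to 160000 nM.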

Compound 4, half-maximal inhibitory concentration: 18000 nM
Beside the measured number, compound 4's estimate is 4.2-fold (0.62 log units) above it; measured number outside the range, below it.
By their numbers in this assay, from the lowest: compound 4; then compounds 1, 3 and 2 (each within the scatter of the next).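

In this assay, this position on an aromatic carbon of a five-membered aromatic ring now shows that it can respond to a side-chain change: a 4.2-fold lower number from compound 1 to compound 4 (0.62 log units; beyond the scatter), and the step is of similar size against the two triazole compounds, a 4.2-fold lower number from compound 3 to compound 4 (0.62 log units; beyond the scatter) and a 4.6-fold lower number from compound 2 to compound 4 (0.66 log units; beyond the scatter). The earlier swaps all kept the saturated chain carbon and stayed within the scatter, even with the phenyl of compound 3 in the side chain, so a phenyl group alone does not go with the lower number; the step appears only in compound 4, where the saturated chain carbon is gone and a double bond outside aromatic rings links the phenyl group to the shared core. No measurement at hand gives a reason for this step.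

The compounds shown do not tell whether the double bond, the loss of the triazole or piperazine ring, or the shorter path to the phenyl group carries the step. A saturated 2-phenylethyl chain or a phenyl group set directly on the same aromatic carbon would pull these parts apart, and an amine on the phenyl ring of the 2-phenylethenyl group would test how much that ring tolerates.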